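Removing a Methoxy Group from a Shared Ketone Core

This account rests on a few compounds, and the source may have more. Where it says the series, first, only, none or still open, it means among the compounds named here.

Three measured compounds share one core. Compound 1 `COc1ccc(CCC(=O)c2cccc(O)c2)cc1`, compound 2 `COc1ccc(CCC(=O)c2cccc(O)c2)c(OC)c1` and compound 3 `COc1ccc(C(=O)CCc2ccc(OC)c(OC)c2)c(O)c1` were tested in an ADME assay on RAW264.7 cells (Mus musculus) for cytotoxicity, read by MTT assay, with a stated time of 24 h, tested at 2.5 ug/mL; on this read-out higher numbers stand for a weaker effect at the one concentration tested and lower numbers for a stronger effect. Compound 1 gives 97.1%, compound 2 gives 88.5% and compound 3 gives 89%. The change from compound 2 to compound 1 is hydrogen in place of methoxy on an aromatic carbon; it gave a number 8.6 percentage points higher from compound 2 to compound 1 (within the scatter). The difference between the cores of compound 2 and compound 3 is not broken down here. Compound 4 `COc1ccc(CCC(=O)c2ccc(OC)cc2O)cc1` has not been measured. It arises from compound 3 by hydrogen in place of methoxy on an aromatic carbon, the same kind of change, though here the place is ortho to a methoxy group and meta to a large group, rather than ortho to a large group and meta to a methoxy group. Because the earlier step of a number 8.6 percentage points higher from compound 2 to compound 1 (within the scatter) stayed within the scatter, a similarly small step is expected, a number 4 percentage points higher from compound 3 to compound 4 (within the scatter). Compound 4 is therefore estimated to give 93% in this assay, with a likely range from 84% to 100%.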

Compound 4, a percentage reported as activity, at one concentration (the size of the read-out at that concentration, not a potency): 94.5%
For compound 4 the middle estimate is 1.5 percentage points below the measured one; low and high end bracket the measured number.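

In this assay, hydrogen in place of methoxy on an aromatic carbon gave a number 5.5 percentage points higher from compound 3 to compound 4 (within the scatter), and the step is of similar size on the two cores: the same change on two cores in this assay, a number 8.6 percentage points higher (within the scatter) from compound 2 to compound 1 and a number 5.5 percentage points higher (within the scatter) from compound 3 to compound 4, 3.1 percentage points apart, within the scatter of two such steps. Within this small set, then, the change carries from one core to the other with no detectable difference. However, each step on its own lies within the scatter, so neither shows that the change has a real effect, and two cores cannot establish a rule for the wider series.

The compounds shown leave open whether the same holds when methoxy gives way to another group, such as an amine or a carboxylic acid. Also open, from the compounds shown here alone, is how these compounds behave at any concentration other than the single one tested.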